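Carboxy for methoxy on the aryl ring of a thione

A few compounds are considered here, and "the series" means these few. Any claim that something is new, unique, unknown or untested is made for them only; others in the source may bear on it.

This account concerns three compounds sharing one core. Compound 1 `COc1ccccc1-c1csc(=S)[nH]1` carries a methoxy group on its aromatic ring, and in an assay on isolated protein for inhibition of Indoleamine 2,3-dioxygenase 1 (Homo sapiens), read by colorimetric assay, with stated times of 10 min and 30 min, tested at 100 uM (on this read-out lower numbers stand for less inhibition and higher numbers for more inhibition at the one concentration tested (going by the name of the read-out)), compound 1 gives 53%. Compound 2 `OCc1cccc(-c2csc(=S)[nH]2)c1` carries a hydroxymethyl group instead, and in this assay compound 2 gives 16%. Of the two numbers measured, compound 1 stands highest; the number for compound 2 lies below it by a gap that goes beyond the usual scatter. Compound 3 `O=C(O)c1ccccc1-c1csc(=S)[nH]1` has not yet been measured. It differs from compound 1 in one place: carboxy in place of methoxy on an aromatic carbon. Going by the values given here, no measured pair in this set shows the same kind of change. Among the compounds with values here, the expected step from compound 1 to compound 3, a number 21 percentage points lower from compound 1 to compound 3 (beyond the scatter), is a modest fall that may reach beyond the scatter, since the only other change in the set, at compound 2 with 16%, lowered the read-out. Compound 3 is therefore estimated to give 32%, with a range from 8% to 58%.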

Compound 3, a percentage reported as inhibition, at one concentration (the size of the read-out at that concentration, not a potency): 8%
Estimate against measurement, compound 3: 24 percentage points above; the range from low to high includes it.
By their numbers in this assay, from the lowest: compounds 3 and 2 (each within the scatter of the next); then compound 1.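

Carboxy in place of methoxy on this aromatic carbon, ortho to a group of 6 heavy atoms, gives a number 45 percentage points lower from compound 1 to compound 3 (beyond the scatter) in this assay. Going by these compounds alone, this is the first one-place change in the set, and it shows that the read-out at this position does not hold up under this replacement: the methoxy of compound 1 cannot be exchanged for carboxy without a large loss of inhibition at the one concentration tested. Nothing available here explains the fall. The compounds shown leave open how an amine, an ethoxy group or a longer chain on this same aromatic carbon would read in this assay. They also leave open whether carboxy on a different carbon of the ring would bring a fall of the same size.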